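The source may hold more compounds than are shown below. What is called first, only, known or untested is meant among the compounds shown, and "the series" means these compounds.

Compound 1 `COc1ccc(/C=C(\C#N)C(=O)N/N=C(\C)c2c(O)c3ccc(O)cc3oc2=O)cc1OC`: 45300 nM
Compound 2 `COc1ccc(/C=C(\C#N)C(=O)N/N=C(\C)c2c(O)c3ccc(O)cc3oc2=O)cc1`: 96100 nM
Compound 3 `COc1cc(/C=C(\C#N)C(=O)N/N=C(\C)c2c(O)c3ccc(O)cc3oc2=O)cc(OC)c1OC`: 55300 nM

In a functional assay on NRK-49F cells (Rattus norvegicus) for cytotoxicity, read by MTT assay, with a stated time of 24 h (a higher number here means a weaker inhibitor, a lower number a stronger inhibitor), compound 1 stands at the low end of the three numbers. The nearest step is a 1.2-fold higher number from compound 1 to compound 3 (0.09 log units; within the scatter), and the furthest is a 2.1-fold higher number from compound 1 to compound 2 (0.33 log units; beyond the scatter).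

Compound 4 `C/C(=N\NC(=O)/C(C#N)=C/c1cccc([N+](=O)[O-])c1)c1c(O)c2ccc(O)cc2oc1=O` has not yet been measured. Its difference from compound 1 is 3-nitrophenyl in place of 3,4-dimethoxyphenyl on a double-bonded chain carbon bound to a double-bonded chain carbon.

Among the compounds with values here, both measured steps only add or remove a methoxy on this aromatic ring, and no measured compound carries a nitro group, so they bear on the change only loosely. The larger step, to compound 2 at 96100 nM, was modest, so a step of similar small size is expected, tilted weakly towards a higher number. The estimated step is a 1.4-fold higher number from compound 1 to compound 4 (0.16 log units; within the scatter). In this assay the expected value for compound 4 is 65000 nM, with an estimated range from 28000 nM to 140000 nM.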

Compound 4, half-maximal inhibitory concentration: 46500 nM
Beside the measured number, compound 4's estimate is 1.4-fold (0.15 log units) above it, and the stated range covers the measured number.
By their numbers in this assay, from the lowest: compounds 1, 4, 3 and 2 (each within the scatter of the next, the first and the last beyond it).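

In this assay, within the data shown here, exchanging the whole aryl group on a double-bonded chain carbon bound to a double-bonded chain carbon gives a 1.0-fold higher number from compound 1 to compound 4 (0.01 log units; within the scatter), so 3-nitrophenyl and 3,4-dimethoxyphenyl read alike here, whereas the earlier compounds had varied only the methoxy groups on this ring. The second step, a 2.1-fold lower number from compound 2 to compound 4 (0.32 log units; beyond the scatter), places the nitro compound with compound 1 rather than with compound 2, which shows that methoxy groups are not needed on this ring for a number in the range of compound 1. Nothing available explains why these two different groups read alike.

The compounds shown leave open whether this tolerance extends to a ring carrying an amine or a carboxylic acid. They also leave open whether an unsubstituted phenyl would read with compound 1 or with compound 2.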